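Working notes on compounds 1 to 4

A few compounds are considered here, and "the series" means these few. Any claim that something is new, unique, unknown or untested is made for them only; others in the source may bear on it.

Measured so far:
- Compound 1 `NC1=NC2(CCSCC2)N(OCCCOc2ccc(Cl)c(Cl)c2)C(N)=N1` gives 89.8% in an assay on isolated protein for inhibition of Dihydrofolate reductase (Homo sapiens), read by spectrophotometry, using NADPH, with stated times of 5 s and 6 min, tested at 50 uM; a higher number here means a stronger effect of the compound at the concentration tested, a lower number a weaker effect.
- Compound 2 `NC1=NC2(CCSCC2)N(OCCCOc2cccc(Cl)c2)C(N)=N1` gives 88.8% in this assay.
- Compound 3 `NC1=NC2(CCSCC2)N(OCCCOc2cc(Cl)c(Cl)cc2Cl)C(N)=N1` gives 94.4% in this assay.

Among the compounds with values here, compound 3 carries the highest of the three numbers, but the gaps are small: a number 4.6 percentage points higher from compound 1 to compound 3 (within the scatter) and a number 5.6 percentage points higher from compound 2 to compound 3 (within the scatter), so no compound stands apart. Likewise a number 1 percentage points lower from compound 1 to compound 2 (within the scatter).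

Compound 4 `NC1=NC2(CCSCC2)N(OCCCOc2ccccc2Br)C(N)=N1` differs from compound 3 by one change: 2-bromophenyl in place of 2,4,5-trichlorophenyl on an oxygen on a saturated carbon. All three measured steps exchange chloro substitution on this same ring, and none moved the read-out beyond the scatter. A bromophenyl is not covered by any measured step, so the expectation rests on the chloro steps alone. No step beyond the scatter is therefore expected in this assay. Compound 4 is estimated at 87%, with a range of 72% to 96%. The expected step is a number 7.4 percentage points lower from compound 3 to compound 4 (within the scatter).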

Compound 4, a percentage reported as inhibition, at one concentration (the size of the read-out at that concentration, not a potency): 89.6%
Estimate against measurement, compound 4: 2.6 percentage points below; the measured number falls inside the stated range.
By their numbers in this assay, from the lowest: compounds 2, 4, 1 and 3 (each within the scatter of the next).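

A bromine now joins chlorine on the aryl group on an oxygen on a saturated carbon, and 2-bromophenyl leaves the read-out in this assay level with all three chlorinated rings (a number 4.8 percentage points lower from compound 3 to compound 4 (within the scatter); a number 0.8 percentage points higher from compound 2 to compound 4 (within the scatter); a number 0.2 percentage points lower from compound 1 to compound 4 (within the scatter)). At this place, neither exchanging chlorine for bromine nor the difference between one halogen and three gives a step beyond the scatter. Nothing available explains this flat result. From the compounds shown here alone, whether an unsubstituted phenyl, a ring bearing an amine or a carboxylic acid, or a longer chain would shift the read-out stays open. Read-outs at a single concentration also leave open whether these four compounds would show a stronger or weaker effect relative to one another at any other concentration.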